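Notes on a methyl-to-chloro exchange in a small series

A few compounds are considered here, and "the series" means these few. Any claim that something is new, unique, unknown or untested is made for them only; others in the source may bear on it.

Compound 1 `C=C(Br)C(=O)Nc1cccc(-c2cn3nc(-c4ccc(C)cc4)sc3n2)c1` is the reference point. Going by the values given here, in a functional assay on HeLa cells (Homo sapiens) for inhibition, read by cell counting, with a stated time of 4 days (on this read-out lower numbers stand for stronger inhibition and higher numbers for weaker inhibition), compound 1 gives 2000 nM, the lowest of the two numbers recorded so far; its only neighbour is compound 2 `Cc1ccc(-c2nn3cc(-c4cccc(N)c4)nc3s2)cc1`, which in this assay gives 8900 nM. Among the compounds with values here, the single measured step, a 4.5-fold higher number from compound 1 to compound 2 (0.65 log units; beyond the scatter), covers hydrogen in place of (1-bromoethenyl)carbonyl on a nitrogen on an aromatic ring, and it lies beyond the scatter.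

Compound 3 `C=C(Br)C(=O)Nc1cccc(-c2cn3nc(-c4ccc(Cl)cc4)sc3n2)c1` keeps the (1-bromoethenyl)carbonyl group on the nitrogen and differs from compound 1 by chloro in place of methyl on an aromatic carbon of a six-membered aromatic ring of carbon only, para to a large group, or, cut one bond further out, 4-methylphenyl to 4-chlorophenyl. Within the data shown here, no measured step touches this part of the molecule; the step from compound 1 to compound 2 concerns a different site and says nothing about a methyl-to-chloro exchange. With nothing pointing either way, the expected step of no change at the digits printed from compound 1 to compound 3 (within the scatter) in this assay is none beyond the scatter. Compound 3 is therefore estimated at 2000 nM in this assay, with a range from 700 nM to 6000 nM.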

Compound 3, half-maximal inhibitory concentration: 3000 nM
The estimate for compound 3 lay 1.5-fold (0.18 log units) below the measured number; low and high end bracket the measured number.
By their numbers in this assay, from the lowest: compounds 1 and 3 (each within the scatter of the next); then compound 2.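

In this assay, the exchange of 4-methylphenyl for 4-chlorophenyl on the shared core gives a 1.5-fold higher number from compound 1 to compound 3 (0.18 log units; within the scatter), so at this place, para to a large group, chloro in place of methyl produces no change that can be told from the scatter. Going by these compounds alone, this is the only reading at this site, since the other step, a 4.5-fold higher number from compound 1 to compound 2 (0.65 log units; beyond the scatter), concerns the (1-bromoethenyl)carbonyl group on the nitrogen, and that group stands in both compound 1 and compound 3, so the reading holds only with that group present. No independent data on these compounds bear on this result.

What the compounds shown leave open is whether this place also accepts groups of another kind, such as a methoxy group, an amine, a carboxylic acid or a longer chain, in place of methyl or chloro, since two small groups say little about the range of the site. Also open, going by these compounds, is whether chloro behaves the same way when the nitrogen carries hydrogen, as in compound 2, in place of the (1-bromoethenyl)carbonyl group.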